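Aryl hydrazone variation in a urea series

This account rests on a few compounds, and the source may have more. Where it says the series, first, only, none or still open, it means among the compounds named here.

Measured compounds:
compound 1 `CN(C)CCn1cnnc1-c1cc(Oc2ccc(NC(=O)N/N=C/c3ccc(F)cc3)cc2F)ccn1` — 1980 nM
compound 2 `CN(C)CCn1cnnc1-c1cc(Oc2ccc(NC(=O)N/N=C/c3ccc(F)cc3F)cc2F)ccn1` — 1930 nM

In a functional assay on NCI-H460 cells (Homo sapiens) for cytotoxicity, read by MTT assay, with a stated time of 72 h (on this read-out higher numbers stand for weaker inhibition and lower numbers for stronger inhibition), compound 1 gives 1980 nM, and compound 2 gives 1930 nM. Compound 2 stands lowest of the two numbers, but its gap to compound 1 is within the scatter, so no order between them is claimed. Within the data shown here, the single measured step, a 1.0-fold lower number from compound 1 to compound 2 (0.01 log units; within the scatter), is the only guide available.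

Compound 3 `CN(C)CCn1cnnc1-c1cc(Oc2ccc(NC(=O)N/N=C/c3ccc(O)c(F)c3)cc2F)ccn1` differs from compound 2 in one place: 3-fluoro-4-hydroxyphenyl in place of 2,4-difluorophenyl on a carbon with a double bond to nitrogen. Among the measured compounds shown here, the measured step concerned only a fluoro entering on an aromatic carbon and did not move the read-out; no measured step touches a hydroxyl, so the effect of the entering group is not covered by the data. With nothing pointing either way, the expectation for compound 3 is a step of a 1.0-fold higher number from compound 2 to compound 3 (0.02 log units; within the scatter), that is none beyond the scatter. Compound 3 is estimated at 2000 nM, with a range of 700 nM to 6000 nM.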

Compound 3, half-maximal inhibitory concentration: 2620 nM
For compound 3 the middle estimate is 1.3-fold (0.12 log units) below the measured one; measured number inside the range.
By their numbers in this assay, from the lowest: compounds 2, 1 and 3 (each within the scatter of the next).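

At the carbon with a double bond to nitrogen, 3-fluoro-4-hydroxyphenyl in place of 2,4-difluorophenyl gives a 1.4-fold higher number from compound 2 to compound 3 (0.13 log units; within the scatter) in this assay, and 3-fluoro-4-hydroxyphenyl in place of 4-fluorophenyl gives a 1.3-fold higher number from compound 1 to compound 3 (0.12 log units; within the scatter). The earlier pair varied only fluoro on the aryl ring, whereas these steps bring in a hydroxyl, with its hydrogen-bond donor, and neither step lies beyond the scatter. No measurement is available that would offer an explanation for this result.

Each step to compound 3 alters hydroxyl and fluoro together, so the contribution of the hydroxyl alone stays unresolved, and a 4-hydroxyphenyl group would separate the two. As far as these compounds go, it also stays open whether a methoxy, an amine or a carboxylic acid on this aryl ring would shift the read-out beyond the scatter.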